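The compounds below may be only part of what the source reports. "The series", "measured", "known", "first", "only" and "open" are said of these compounds alone.

Measured in a functional assay on MDA-MB-231 cells (Homo sapiens) for inhibition, read by MTT assay, with a stated time of 48 h; on this read-out lower numbers stand for stronger inhibition and higher numbers for weaker inhibition:
- compound 1 `COc1cc(-c2cc(-c3ccc(C)cc3)nc(-c3ccccc3)n2)cc(OC)c1OC`: 5110 nM
- compound 2 `COc1ccc(-c2cc(-c3cc(OC)c(OC)c(OC)c3)nc(-c3ccccc3)n2)c(OC)c1`: 1440 nM
- compound 3 `COc1cc(-c2cc(-c3cccc(O)c3)nc(-c3ccccc3)n2)cc(OC)c1OC`: 1990 nM

Compound 3 cannot be separated from compound 2, as a 1.4-fold higher number from compound 2 to compound 3 (0.14 log units; within the scatter) shows, but it is separated from compound 1, as a 2.6-fold lower number from compound 1 to compound 3 (0.41 log units; beyond the scatter) shows. Compound 4 `COc1ccc(-c2cc(-c3cc(OC)c(OC)c(OC)c3)nc(-c3ccccc3)n2)cc1` differs from compound 3 by one change, 4-methoxyphenyl in place of 3-hydroxyphenyl on an aromatic carbon.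

Among the compounds with values here, no measured step makes this exact exchange. The nearest evidence comes from the two related groups, 4-methylphenyl and 2,4-dimethoxyphenyl, which are linked by a 3.5-fold lower number from compound 1 to compound 2 (0.55 log units; beyond the scatter). The entering 4-methoxyphenyl resembles both, so its number in this assay is expected to fall between those of compound 1 and compound 2, which also bracket compound 3. A small rise at most, not clearly beyond the scatter, is therefore expected. The expected step is a 1.3-fold higher number from compound 3 to compound 4 (0.12 log units; within the scatter). For compound 4 the estimate is 2600 nM, with an expected range from 1100 nM to 5800 nM.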

Compound 4, half-maximal inhibitory concentration: 3390 nM
Compound 4: middle estimate off by 1.3-fold (0.12 log units), on the low side; measured number inside the range.
By their numbers in this assay, from the lowest: compounds 2, 3, 4 and 1 (each within the scatter of the next, the first and the last beyond it).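

In this assay, within the data shown here, the first direct reading of a group with a hydrogen-bond donor against one without at this position is a 1.7-fold higher number from compound 3 to compound 4 (0.23 log units; within the scatter), so 3-hydroxyphenyl and 4-methoxyphenyl cannot be separated here. The second methoxy of 2,4-dimethoxyphenyl does separate two compounds, with a 2.4-fold higher number from compound 2 to compound 4 (0.37 log units; beyond the scatter), whereas exchanging methyl for methoxy at the 4-position of the phenyl group gives only a 1.5-fold lower number from compound 1 to compound 4 (0.18 log units; within the scatter), and this small step does not separate them. Nothing given here accounts for these steps.

The exchange between 3-hydroxyphenyl and 4-methoxyphenyl alters both the group and where it sits on the phenyl ring, leaving open what 3-methoxyphenyl or 4-hydroxyphenyl would give. On these data alone, it also remains open how an amine, a carboxylic acid or a longer chain such as butoxy on that ring would behave.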